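The source may hold more compounds than are shown below. What is called first, only, known or untested is meant among the compounds shown, and "the series" means these compounds.

Values so far in an ADME assay on BHK-21 cells (Mesocricetus auratus) for cytotoxicity, read by MTT assay (on this read-out lower numbers stand for higher toxicity in this test and higher numbers for lower toxicity in this test), each a limit of the assay and not a number:
- compound 1 `CC(=O)c1ccc2[nH]c(-c3ccccc3)nc2c1`: > 100000 nM
- compound 2 `CC(=O)c1ccc2[nH]c(-c3ccc(Cl)cc3)nc2c1`: > 100000 nM
- compound 3 `C/C(=N\O)c1ccc2[nH]c(-c3ccccc3)nc2c1`: > 100000 nM

Compound 3 gives only a limit, > 100000 nM. Among the compounds with values here, the series so far stands at the limit of > 100000 nM in this assay, at which 3 of the 3 values shown sit.

Compound 4 `C/C(=N\O)c1ccc2[nH]c(-c3ccc(Cl)cc3)nc2c1` has chloro in place of hydrogen on an aromatic carbon of compound 3: chloro in place of hydrogen on an aromatic carbon. Within the data shown here, the closest precedent is the same exchange, a step that the two limits leave unreadable from compound 1 to compound 2. The other measured step, a step that the two limits leave unreadable from compound 1 to compound 3, gives no size either. Among the measured compounds shown here, no step of readable size therefore bears on this change, and no step beyond the scatter is expected in this assay, in either direction.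

The expected step is a step that the limit leaves unreadable from compound 3 to compound 4. Compound 4 is estimated at 130000 nM, with an expected range of 70000 nM to 300000 nM, most likely reported only as a limit.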

Compound 4, half-maximal cytotoxic concentration: 33000 nM
Beside the measured number, compound 4's estimate is 3.9-fold (0.60 log units) above it; measured number outside the range, below it.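

In this assay, within the data shown here, the step of an at least 3.0-fold lower number from compound 3 to compound 4 (0.48 log units; beyond the scatter) is the first readable result for chloro in place of hydrogen on this aromatic carbon, para to a large group. With chloro present, an at least 3.0-fold lower number from compound 2 to compound 4 (0.48 log units; beyond the scatter) follows from the group of 4 heavy atoms in place of the group of 3 heavy atoms, so each change reads only in the presence of the other. The remaining steps cannot be read, and only compound 4 gives a number rather than a limit: the limit of > 100000 nM in this assay, at which 3 of the 4 values shown sit.

Going by these compounds, the full size of both steps stays open. Also open, on these data alone, is whether fluoro, methoxy or an amine, para to a large group, would give the same lowering as chloro.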